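The compounds below may be only part of what the source reports. "The series", "measured", "known", "first", "only" and "open" are said of these compounds alone.

Compound 1 `CCCCCCC[C@H]1C[C@H](Cl)CCN1S(=O)(=O)c1ccc(C)cc1` and compound 2 `Cc1ccc(S(=O)(=O)N2CC[C@@H](Cl)C[C@@H]2C2CCCCC2)cc1` are built on one core, while compound 3 `CCCCCCCC1C=C(Cl)CCN1S(=O)(=O)c1ccc(C)cc1` and compound 4 `Cc1ccc(S(=O)(=O)N2CCC(Cl)=CC2C2CCCCC2)cc1` are built on another; the difference between the two cores is not broken down here. All were examined in a functional assay on A2780 cells (Homo sapiens) for antiproliferative activity, read by sulforhodamine B assay, with a stated time of 48 h; on this read-out higher numbers stand for weaker inhibition of growth and lower numbers for stronger inhibition of growth. For compound 1 the result in this assay is a limit of the assay, > 100000 nM. Compound 2 gives 72000 nM in this assay. Compound 3 gives 92000 nM in this assay, and the values of compound 2 and compound 3 lie within the scatter of each other.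

Compound 1 and compound 2 differ in one place: cyclohexyl in place of heptyl on a saturated ring carbon. This change produced an at least 1.3-fold lower number from compound 1 to compound 2 (0.14 log units; that floor lies within the scatter), and the step can only be given as a floor because the limit of > 100000 nM in this assay, at which 1 of the 3 values shown sits, is where compound 1 sits.

Compound 3 and compound 4 differ in exactly the same place and in the same way: cyclohexyl in place of heptyl on a saturated ring carbon. Since the surroundings of the change are the same word for word in both pairs, the change is the same one. On this basis the step from compound 3 to compound 4 is expected to be a 1.4-fold lower number from compound 3 to compound 4 (0.15 log units; within the scatter), which rests on the measured move an at least 1.3-fold lower number from compound 1 to compound 2 (0.14 log units; that floor lies within the scatter) and on the value that compound 3 gives, 92000 nM. Compound 4 is therefore estimated to give 65000 nM in this assay. The expected range for compound 4 runs from 30000 nM to 150000 nM.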

Compound 4, concentration for 50% growth inhibition: 39000 nM
For compound 4 the middle estimate is 1.7-fold (0.22 log units) above the measured one; measured number inside the range.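

On the second core, putting cyclohexyl in place of heptyl on a saturated ring carbon gives a 2.4-fold lower number from compound 3 to compound 4 (0.37 log units; beyond the scatter) in this assay. Set beside the earlier step, the change points the same way on both cores, but the comparison of the two sizes stays unresolved: the same change on two cores in this assay, an at least 1.3-fold lower number (0.14 log units; that floor lies within the scatter) from compound 1 to compound 2 and a 2.4-fold lower number (0.37 log units; beyond the scatter) from compound 3 to compound 4; the limit leaves it open whether they differ Compound 1 stands at a limit of the assay, so the pair of compounds shows that the direction of the change carried over to the second core in this one assay, but it does not show that the size carried over, and each core contributes only a single pair: the limit of > 100000 nM in this assay, at which 1 of the 4 values shown sits.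

The compounds shown leave open whether a different group on this saturated ring carbon, such as a phenyl ring, a shorter chain or a chain ending in an amine, would move the number the same way on both cores. They also leave open whether the step from heptyl to cyclohexyl would hold if a bromo or hydroxyl group stood on the ring atom that bears the chloro group.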